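Pyrazin-2-yl to 2-Carboxypyridin-3-yl on a Shared Core

This account rests on a few compounds, and the source may have more. Where it says the series, first, only, none or still open, it means among the compounds named here.

Compound 1 `CCC(C)(C)Cc1c[nH]c(CCc2ccc(-c3cnccn3)cc2)n1`: 100 nM
Compound 2 `CCC(C)(C)Cc1c[nH]c(CCc2ccc(N3CCCCC3)cc2)n1`: 108 nM

In a functional assay on HEK293 cells for agonist activity at Bombesin receptor subtype-3 (Homo sapiens), read by luminescence and calcium flux, with a stated time of 10 min (a higher number here means that more compound is needed for the effect, a lower number that less compound is needed), compound 1 gives 100 nM, the lowest of the two numbers. Compound 2 gives 108 nM, and a 1.1-fold higher number from compound 1 to compound 2 (0.03 log units; within the scatter). Compound 3 `CCC(C)(C)Cc1c[nH]c(CCc2ccc(-c3cccnc3C(=O)O)cc2)n1` differs from compound 1 in one place: 2-carboxypyridin-3-yl in place of pyrazin-2-yl on an aromatic carbon. Within the data shown here, the only measured step also exchanged pyrazin-2-yl at this place and stayed within the scatter, so little movement is expected, though no measured step speaks to a 2-carboxypyridin-3-yl group itself. For compound 3 the expected value is 150 nM (range 40 nM to 600 nM), which is the estimated step of a 1.5-fold higher number from compound 1 to compound 3 (0.18 log units; within the scatter).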

Compound 3, half-maximal effective concentration: 95 nM
For compound 3 the middle estimate is 1.6-fold (0.20 log units) above the measured one; low and high end bracket the measured number.
By their numbers in this assay, from the lowest: compounds 3, 1 and 2 (each within the scatter of the next).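

In this assay the swap to 2-carboxypyridin-3-yl adds heavy atoms and a hydrogen-bond donor to this place, yet it gives a 1.1-fold lower number from compound 1 to compound 3 (0.02 log units; within the scatter) and shows that a carboxylic acid can sit here with no change beyond the scatter. Measured against piperidin-1-yl, the same group gives a 1.1-fold lower number from compound 2 to compound 3 (0.06 log units; within the scatter) and all three groups at this place, on an aromatic carbon para to a large group, now lie within the scatter of one another. No measurement at hand explains this result.

The compounds shown leave open how a methyl ester or a primary amide in place of the carboxylic acid would read. They also leave open whether a plain phenyl ring or a primary amine at this place would move the number beyond the scatter.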